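Compound 4: trifluoromethyl in place of methyl

This account rests on a few compounds, and the source may have more. Where it says the series, first, only, none or still open, it means among the compounds named here.

Values in a functional assay on MCF7 cells (Homo sapiens) for cytotoxicity, read by sulforhodamine B assay, with a stated time of 48 h; a higher number here means a weaker inhibitor, a lower number a stronger inhibitor:
- compound 1 `Nc1nccc(-c2cnc3ccccc3c2)n1`: > 50000 nM (a limit of the assay, not a number)
- compound 2 `Cc1ccc(Nc2nccc(-c3c(C)nc4ccccn34)n2)cc1`: 59 nM
- compound 3 `Cc1nc2ccccn2c1-c1ccnc(Nc2ccc(C=O)s2)n1`: 4270 nM

Compound 2 at 59 nM stands lowest of the two actual numbers, and compound 3 at 4270 nM stands higher. The next compound to be measured in this assay is compound 4 `Cc1nc2ccccn2c1-c1ccnc(Nc2ccc(C(F)(F)F)cc2)n1`, which differs from compound 2 by trifluoromethyl in place of methyl on an aromatic carbon, para to a large group (trifluoromethyl in place of methyl on an aromatic carbon).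

Among the compounds with values here, only one measured step bears on this change: a 72-fold higher number from compound 2 to compound 3 (1.86 log units; beyond the scatter). That large step replaced the whole 4-methylphenyl with 5-formylthiophen-2-yl, whereas the new change leaves the six-membered aromatic ring in place and swaps only the group on it. A step of that size is therefore not expected here, though the data give no firm direction. The expected step is small, leaning slightly towards a higher number: a 1.7-fold higher number from compound 2 to compound 4 (0.23 log units; within the scatter). For compound 4 the estimated value is 100 nM, with an expected range of 20 nM to 500 nM.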

Compound 4, half-maximal inhibitory concentration: 66 nM
Estimate against measurement, compound 4: 1.5-fold (0.18 log units) above, and the stated range covers the measured number.
By their numbers in this assay, from the lowest: compounds 2 and 4 (each within the scatter of the next); then compound 3. At a limit, above all of these: compound 1.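

In this assay, trifluoromethyl in place of methyl on an aromatic carbon, para to a large group, gives a 1.1-fold higher number from compound 2 to compound 4 (0.05 log units; within the scatter). Within the data shown here, the only earlier step at this nitrogen substituent replaced the whole 4-methylphenyl, giving a 72-fold higher number from compound 2 to compound 3 (1.86 log units; beyond the scatter), so it could not separate the ring from the group on it; this pair shows that with the six-membered aromatic ring kept, four heavy atoms can enter here in place of one with no step beyond the scatter. Nothing measured on these compounds bears on the cause of this result.

The compounds shown leave open whether an amine or a carboxylic acid on this carbon would also stay within the scatter of compound 2. They also leave open whether the large step to compound 3 belongs to the thiophene ring or to its formyl group.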